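The source may report more compounds than this note shows. Statements on the series, on what has been measured and on what is new or still open speak of the compounds shown alone.

Compound 1 `CC(=O)OC/C1=C/C[C@](C)(CCC=C(C)C)/C=C/[C@@H](OC(=O)C=C(C)C)[C@](C)(O)/C=C/C1=O`: 2950 nM
Compound 2 `CC(=O)O[C@]1(C)/C=C/C(=O)/C(CO)=C\C[C@](C)(CCC=C(C)C)/C=C/[C@H]1OC(=O)C=C(C)C`: 2370 nM
Compound 3 `C=C1/C=C/C(=O)/C(CO)=C\C[C@](C)(CCC=C(C)C)/C=C/[C@H]1OC(=O)C=C(C)C`: 2810 nM

In a functional assay on HL-60 cells (Homo sapiens) for antiproliferative activity, read by MTT assay, with a stated time of 48 h (a lower number here means a stronger inhibitor, a higher number a weaker inhibitor), compound 1 gives 2950 nM, which lies within the scatter of the other two numbers, so the three compounds sit level. Compound 4 `CC(C)=CCC[C@]1(C)/C=C/[C@@H](OC(=O)C=C(C)C)[C@](C)(O)/C=C/C(=O)/C(CN(C(C)C)C(C)C)=C\C1` departs from compound 1 by one change: diisopropylamino in place of acetoxy on a saturated chain carbon bound to a double-bonded ring carbon. Going by the values given here, no measured pair shows what this exchange does, so the data offer no direct guide. In this assay no step beyond the scatter is expected, though a slight lean towards a lower number is allowed for. The expected change is a 1.5-fold lower number from compound 1 to compound 4 (0.17 log units; within the scatter). For compound 4 the estimated value is 2000 nM, with an expected range of 700 nM to 6000 nM.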

Compound 4, half-maximal inhibitory concentration: 740 nM
The estimate for compound 4 lay 2.7-fold (0.43 log units) above the measured number, within the range that was stated.
By their numbers in this assay, from the lowest: compound 4; then compounds 2, 3 and 1 (each within the scatter of the next).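

Going by these compounds alone, at the saturated chain carbon bound to a double-bonded ring carbon, the earlier compounds gave no step to read, as compound 1, compound 2 and compound 3 sit level. In this assay, diisopropylamino in place of acetoxy gives a 4.0-fold lower number from compound 1 to compound 4 (0.60 log units; beyond the scatter), showing that the group at this place can move the number beyond the scatter. Nothing available accounts for this step. The compounds shown leave open whether another amine, such as dimethylamino or piperidine, would give a similar number at this place.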